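A few compounds are considered here, and "the series" means these few. Any claim that something is new, unique, unknown or untested is made for them only; others in the source may bear on it.

Working notes on the series. Compound 1 `COc1ccc2c(O)c(C(=O)O)cnc2c1` sits at the weak end of the set: in a functional assay on Ehrlich cells (Mus musculus) for inhibition (a lower number here means a stronger inhibitor, a higher number a weaker inhibitor), compound 1 gives 525000 nM, the highest of the three numbers recorded. Compound 2 `O=C(O)c1cnc2cc(OCc3cccc4ccccc34)ccc2c1O` gives 85100 nM and compound 3 `O=C(O)c1cnc2cc(OCc3c(Cl)c(Cl)c(Cl)c(Cl)c3Cl)ccc2c1O` gives 42700 nM in this assay, both beyond the scatter from compound 1, so compound 1 is the weakest inhibitor measured so far. Within the data shown here, no single-point step between measured compounds is available to calibrate the change now under consideration.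

Compound 4 `CC(=O)c1ccc2c(O)c(C(=O)O)cnc2c1` differs from compound 1 by acetyl in place of methoxy on an aromatic carbon. Neither compound 2 nor compound 3 informs this change, so no step beyond the scatter is expected in this assay. Compound 4 is estimated at 400000 nM, within 150000 nM to 1000000 nM. The expected step of a 1.3-fold lower number from compound 1 to compound 4 (0.12 log units; within the scatter) is thus small.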

Compound 4, half-maximal inhibitory concentration: 794000 nM
The estimate for compound 4 lay 2.0-fold (0.30 log units) below the measured number, within the range that was stated.
By their numbers in this assay, from the lowest: compounds 3 and 2 (each within the scatter of the next); then compounds 1 and 4 (each within the scatter of the next).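

Acetyl in place of methoxy on this aromatic carbon gives a 1.5-fold higher number from compound 1 to compound 4 (0.18 log units; within the scatter) in this assay, the first step in the series that differs in one place. At this position, then, the change from methoxy to acetyl, with its double bond outside the aromatic rings, cannot be told from the scatter. Nothing measured on these compounds offers an explanation for this result.

Still open, as far as these compounds go, is whether an amine or a carboxylic acid on the same aromatic carbon would give a step beyond the scatter.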